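The source may report more compounds than this note shows. Statements on the series, on what has been measured and on what is new or still open speak of the compounds shown alone.

Working notes on the series, read in a functional assay on PC-3 cells (Homo sapiens) for antiproliferative activity, read by MTT assay, with a stated time of 72 h; on this read-out lower numbers stand for stronger inhibition and higher numbers for weaker inhibition. Compound 1 (`CCn1c(C(=O)NCc2ccc(OC)cc2)ccc1C(CC)(CC)c1ccc(C#CC(O)(CC)CC)c(C)c1`) gives > 50000 nM, which is a limit of the assay and not a number. Compound 2 (`CCn1c(C(=O)On2nnc3ccccc32)ccc1C(CC)(CC)c1ccc(C#CC(O)(CC)CC)c(C)c1`) gives > 50000 nM, again a limit. Going by the values given here, compound 3 (`CCN(CC)CCNC(=O)c1cc(C(CC)(CC)c2ccc(C#CC(O)(CC)CC)c(C)c2)cn1CC`) gives 5350 nM, the only actual number in the set. Compound 4 (`CCn1cc(C(CC)(CC)c2ccc(C#CC(O)(CC)CC)c(C)c2)cc1C(=O)NCCC(=O)O`) differs from compound 3 by one change: carboxy in place of diethylamino on a saturated chain carbon, two bonds along the chain from an amide-type nitrogen. Among the compounds with values here, the one measured step, a step that the two limits leave unreadable from compound 1 to compound 2, has no readable size and does not involve this chain. Compound 1 and compound 2 both lack the diethylamino group, differ from compound 3 elsewhere too, and share (the limit of > 50000 nM in this assay, at which 2 of the 3 values shown sit). This is thin support, but it points away from compound 3 once that group is gone. The expected step is a 4.7-fold higher number from compound 3 to compound 4 (0.67 log units; beyond the scatter), toward weaker inhibition, and the assay limit may be reached. For compound 4 the estimated value is 25000 nM, with an expected range from 8000 nM to 50000 nM.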

Compound 4, half-maximal inhibitory concentration: > 50000 nM
Compound 4 was reported as a limit; the forecaster's own chance of this, stated with the estimate: 45%; at least 2.0-fold (0.30 log units) between middle value and limit.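

In this assay, this position on the chain is now shown to respond to a single change: carboxy in place of diethylamino on a saturated chain carbon, two bonds along the chain from an amide-type nitrogen, gives an at least 9.3-fold higher number from compound 3 to compound 4 (0.97 log units; beyond the scatter). Compound 4 gives > 50000 nM, which is a limit of the assay and not a number, so the step has a lower bound but no upper one. Compound 3 remains the only compound with an actual number, and the rest of the set sits at one limit: the limit of > 50000 nM in this assay, at which 3 of the 4 values shown sit.

Still open, from the compounds shown here alone, is whether diethylamino itself is required or another amine, such as dimethylamino or piperidine, would serve as well on this chain. This one change also cannot separate the loss of the amine from the arrival of the carboxylic acid, and a simple hydroxy group or a longer chain would be needed to tell them apart.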